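The source may report more compounds than this note shows. Statements on the series, on what has been measured and on what is new or still open speak of the compounds shown alone.

Compound 1 `O=S(=O)(Nc1ccc(-c2nc3ccccc3o2)cc1)c1ccc(Cl)c(C(F)(F)F)c1` and compound 2 `O=[N+]([O-])c1cc(S(=O)(=O)Nc2ccc(-c3nc4ccccc4o3)cc2)ccc1Cl` share a core and differ only in one group. In an assay on cells for inhibition of HSP60/HSP10 (Homo sapiens), with a stated time of 60 min (a higher number here means a weaker inhibitor, a lower number a stronger inhibitor), compound 1 gives 12000 nM, and in this assay compound 2 gives 17000 nM; the step of a 1.4-fold higher number from compound 1 to compound 2 (0.15 log units; within the scatter) places the two within the scatter of each other, so neither stands apart. Compound 3 `O=S(=O)(Nc1ccc(-c2nc3ccccc3o2)cc1)c1cccc(C(F)(F)F)c1` is made from compound 1 by hydrogen in place of chloro on an aromatic carbon. No measured step removes a chloro, so the one shown step does not bear on this change, and only a step within the scatter is expected. Compound 3 is therefore estimated at 18000 nM, within 8000 nM to 40000 nM, a change of a 1.5-fold higher number from compound 1 to compound 3 (0.18 log units; within the scatter).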

Compound 3, half-maximal inhibitory concentration: 57000 nM
Beside the measured number, compound 3's estimate is 3.2-fold (0.50 log units) below it, outside the stated range (above it).
By their numbers in this assay, from the lowest: compounds 1 and 2 (each within the scatter of the next); then compound 3.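

In this assay, hydrogen in place of chloro gives a 4.8-fold higher number from compound 1 to compound 3 (0.68 log units; beyond the scatter), the only step shown so far that lies beyond the scatter. This position, ortho to a trifluoromethyl group, is therefore sensitive to what it carries, and with the trifluoromethyl group kept, chloro gives the stronger inhibitor. No measurement available here explains this difference.

As far as these compounds go, whether chloro is special or other groups would serve as well remains open, since a fluoro, a methyl or an amine at this position would be needed to tell. From the compounds shown here alone, whether chloro matters equally alongside the nitro of compound 2 also remains open.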